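The compounds below may be only part of what the source reports. "The series", "measured", "known", "first", "only" and "open" are said of these compounds alone.

Measured so far:
- compound 1 `COc1ccc(C(=O)/C=C/c2cc(-c3cc(OC)c(OC)c(OC)c3)n[nH]2)cc1OC` gives 96% in a functional assay on IGROV-1 cells (Homo sapiens) for cytotoxicity, read by sulforhodamine B assay, with a stated time of 48 h, tested at 0.1 uM; a lower number here means a stronger effect, a higher number a weaker effect of the compound at the concentration tested
- compound 2 `COc1ccc(C(=O)/C=C/c2cc(-c3cc(OC)c(OC)c(OC)c3)n[nH]2)cc1` gives 102% in this assay

Compound 1 holds the lowest of the two numbers in this assay, with compound 2 nearest, a number 6 percentage points higher from compound 1 to compound 2 (within the scatter). Both values sit near the level of untreated cells at this concentration, so neither compound shows a clear effect here.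

Compound 3 `COc1cc(C(=O)/C=C/c2cc(-c3cc(OC)c(OC)c(OC)c3)n[nH]2)cc(OC)c1OC` has not been measured. It differs from compound 1 by methoxy in place of hydrogen on an aromatic carbon. Among the measured compounds shown here, the only measured step, a number 6 percentage points higher from compound 1 to compound 2 (within the scatter), runs the opposite way, removing a methoxy group, and stays within the scatter; it therefore offers little guidance on the size or direction of adding one. With compound 1 and compound 2 both near full activity, the expectation is that compound 3 also shows no effect beyond the scatter, and the estimated step of a number 2 percentage points lower from compound 1 to compound 3 (within the scatter) is correspondingly small. Compound 3 is accordingly estimated at 94%, with a range from 78% to 106%.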

Compound 3, a percentage reported as activity, at one concentration (the size of the read-out at that concentration, not a potency): 103%
Compound 3: middle estimate off by 9 percentage points, on the low side; the measured number falls inside the stated range.
By their numbers in this assay, from the lowest: compounds 1, 2 and 3 (each within the scatter of the next).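

Methoxy in place of hydrogen at this position, ortho to a methoxy group and meta to a large group, gives in this assay a number 7 percentage points higher from compound 1 to compound 3 (within the scatter). Read with a number 6 percentage points higher from compound 1 to compound 2 (within the scatter), this shows that neither removing a methoxy group from this ring nor adding one here takes the read-out beyond the scatter, so this position shows no measurable sensitivity to methoxy at the one concentration tested. Nothing available bears on why this change leaves the number within the scatter.

Going by these compounds, whether a different group at this position, such as an amine, a hydroxyl or a carboxylic acid, would move the number beyond the scatter remains open. Also open, on these data alone, is whether compound 1 and compound 3 would separate at higher concentrations, where a full concentration-response reading could show differences that this single-concentration read-out cannot.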